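The source may report more compounds than this note shows. Statements on the series, on what has been measured and on what is new or still open speak of the compounds shown alone.

Compound 1 `NS(=O)(=O)c1cc(-c2nnc(CN3CCN(c4ccccc4)CC3)o2)c(Cl)cc1SCc1ccccc1` and compound 2 `NS(=O)(=O)c1cc(-c2nnc(CN3CCN(c4ccc(Cl)cc4)CC3)o2)c(Cl)cc1SCc1ccccc1` share a core and differ in one place: chloro in place of hydrogen on an aromatic carbon. In a functional assay on HeLa cells (Homo sapiens) for cytotoxicity, read by MTT assay, with a stated time of 72 h (a higher number here means a weaker inhibitor, a lower number a stronger inhibitor), compound 1 gives 100000 nM, and compound 2 gives 11000 nM, so that the change made a 9.1-fold lower number from compound 1 to compound 2 (0.96 log units; beyond the scatter). Compound 3 `NS(=O)(=O)c1cc(-c2nnc(/C=C/c3ccccc3)o2)c(Cl)cc1SCc1ccccc1` carries a different core; the difference between the two cores is not broken down here. In this assay compound 3 gives 14000 nM, which lies within the scatter of the value of compound 2 and beyond it from the value of compound 1.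

Compound 4 `NS(=O)(=O)c1cc(-c2nnc(/C=C/c3cccc(Cl)c3)o2)c(Cl)cc1SCc1ccccc1` is drawn from compound 3 by the same kind of change: chloro in place of hydrogen on an aromatic carbon. The two places are not the same word for word: in compound 2 the chloro stands para to a large group, in compound 4 it stands meta to a large group, and the surrounding parts of the molecule differ as well, so the pair is taken as the same kind of change, not the same change.

The expectation for compound 4 in this assay is a step of a 2.8-fold lower number from compound 3 to compound 4 (0.45 log units; beyond the scatter), smaller than the one seen before, because the earlier step of a 9.1-fold lower number from compound 1 to compound 2 (0.96 log units; beyond the scatter) came in a different setting and at a different place. On that basis compound 4 is estimated at 5000 nM, with a range expected to run from 1500 nM to 15000 nM.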

Compound 4, half-maximal inhibitory concentration: 16000 nM
Compound 4: the middle estimate sits 3.2-fold (0.51 log units) below what was measured; the whole stated range lies below it.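

In this assay, chloro in place of hydrogen on an aromatic carbon, here phenyl to 3-chlorophenyl, gave a 1.1-fold higher number from compound 3 to compound 4 (0.06 log units; within the scatter), so compound 3 and compound 4 cannot be told apart in this cell read-out. Set beside the earlier step, the change does not carry over in size from one core to the other, and the gap between the two steps is real rather than scatter: the same change on two cores in this assay, a 9.1-fold lower number (0.96 log units; beyond the scatter) from compound 1 to compound 2 and a 1.1-fold higher number (0.06 log units; within the scatter) from compound 3 to compound 4, 10-fold (1.02 log units) apart, beyond the scatter of two such steps. Going by these compounds alone, this does not show which difference accounts for the gap, since the two cores differ and the chloro in compound 4, meta to a large group, also stands at a different place from the one in compound 2, and each setting rests on a single pair of compounds.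

The compounds shown leave open whether chloro at the place it holds in compound 2, carried onto the core of compound 3, would give a step like the first one, which would separate the effect of place from that of core. They also leave open whether a bromo or a methoxy group at either place would follow the chloro steps on these two cores.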